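This account rests on a few compounds, and the source may have more. Where it says the series, first, only, none or still open, it means among the compounds named here.

Measured compounds:
Compound 1, `O=C1N(Cc2ccccc2Cl)c2cccn2S(=O)(=O)N1Cc1cccc(Br)c1`: in an ADME assay on MT4 cells (Homo sapiens) for cytotoxicity, read by MTT assay, with a stated time of 5 days (on this read-out lower numbers stand for higher toxicity in this test and higher numbers for lower toxicity in this test), compound 1 gives > 260000 nM, a limit of the test.
Compound 2, `N#Cc1cccc(CN2C(=O)N(Cc3ccccc3)S(=O)(=O)n3cccc32)c1`: in this assay compound 2 gives > 318000 nM, also a limit of the test.

Both readings in this assay are limits rather than numbers. Compound 1 sits at the limit of > 260000 nM in this assay, at which 1 of the 2 values shown sits. Compound 2 sits at the limit of > 318000 nM in this assay, at which 1 of the 2 values shown sits. Compound 2 thus stands at one of the two limits shown, and no order between it and compound 1 can be drawn, as neither gives a number.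

Compound 3, `O=C1N(Cc2cccc(Cl)c2)c2cccn2S(=O)(=O)N1Cc1ccccc1`, has yet to be tested. It differs from compound 2 by chloro in place of cyano on an aromatic carbon. Among the measured compounds shown here, no step between two measured compounds exists to gauge this change. With compound 2 at a limit and nothing to suggest a move in either direction, the step from compound 2 to compound 3 is expected to stay within the scatter, at an at least 1.0-fold lower number from compound 2 to compound 3 (0.02 log units; that floor lies within the scatter). Compound 3 is expected to give about 300000 nM in this assay, with a range from 150000 nM to 600000 nM, most likely reported again as a limit rather than a number.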

Compound 3, half-maximal cytotoxic concentration: 196000 nM
Beside the measured number, compound 3's estimate is 1.5-fold (0.18 log units) above it; the measured number falls inside the stated range.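

With compound 3, the series gains its first actual number in this assay, so the change from 3-cyanobenzyl to 3-chlorobenzyl can now be read at this position, on an aromatic carbon of a six-membered aromatic ring of carbon only, meta to a large group. Chloro in place of cyano gives an at least 1.6-fold lower number from compound 2 to compound 3 (0.21 log units; that floor lies within the scatter); compound 2 reads as a limit, so this figure is only a floor, and the full size of the step remains unknown. Nothing shown gives a reason for this step.

The compounds shown leave open how other groups at the same position, such as an amine, a carboxylic acid or a methoxy group, would read in this assay, and whether any of them would move the number further than chloro does. They also leave open whether chloro in place of cyano would give a similar step on another core, and what compound 2 would give as an actual number rather than a limit, which would fix the size of the step.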